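The source may report more compounds than this note shows. Statements on the series, on what has been measured and on what is new or still open speak of the compounds shown alone.

Compound 1, `NC(=O)C12CCCC3CC(CCC31)C2`, in an ADME assay (Gallus gallus) for cytotoxicity, read by microscopy, with a stated time of 24 h (a lower number here means that less compound is tolerated, a higher number that more compound is tolerated), gives 5200000 nM.
Compound 2, `CNC(=O)C12CCCC3CC(CCC31)C2`, gives 750000 nM in this assay.
Compound 3, `CCCCNC(=O)C12CCCC3CC(CCC31)C2`, gives 300000 nM in this assay.

The three compounds share one core and differ only in what sits on the amide-type nitrogen. Compound 3 stands lowest of the three numbers in this assay; the smaller gap is a 2.5-fold lower number from compound 2 to compound 3 (0.40 log units; beyond the scatter), the larger is a 17-fold lower number from compound 1 to compound 3 (1.24 log units; beyond the scatter).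

Compound 4, `O=C(NC1CCCCC1)C12CCCC3CC(CCC31)C2`, has not yet been measured in this assay. It differs from compound 3 in one place: cyclohexyl in place of butyl on an amide-type nitrogen. Both measured steps bear on this change, as each also enlarges the group on the amide-type nitrogen: a 6.9-fold lower number from compound 1 to compound 2 (0.84 log units; beyond the scatter) and a 2.5-fold lower number from compound 2 to compound 3 (0.40 log units; beyond the scatter). Each enlargement so far has brought a lower number beyond the scatter, the second step smaller than the first. Cyclohexyl is larger than butyl by the count given, so a further modest lowering is expected in this assay, although no measured compound carries a ring on that nitrogen and the size of the step is uncertain. For compound 4 the expected step is a 2.0-fold lower number from compound 3 to compound 4 (0.30 log units; within the scatter). Compound 4 is therefore estimated at 150000 nM, with a range from 60000 nM to 400000 nM.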

Compound 4, minimum cytotoxic concentration: 2250000 nM
For compound 4 the middle estimate is 15-fold (1.18 log units) below the measured one, and the stated range ends below it.
By their numbers in this assay, from the lowest: compound 3; then compound 2; then compound 4; then compound 1.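

With a 7.5-fold higher number from compound 3 to compound 4 (0.88 log units; beyond the scatter) in this assay the downward run on the amide-type nitrogen breaks, so the number of heavy atoms in the group does not by itself order these compounds, and cyclohexyl, with the most heavy atoms of the set, is the compound that goes against that order. Among the compounds shown here, the result also sits apart from both chain-bearing amides and from the unsubstituted one, with a 3.0-fold higher number from compound 2 to compound 4 (0.48 log units; beyond the scatter) and a 2.3-fold lower number from compound 1 to compound 4 (0.36 log units; beyond the scatter) placing cyclohexyl inside the span the earlier compounds had marked out: every group on that nitrogen still gives a lower number than hydrogen, but the ring gives up most of the lowering that butyl had reached. No measured evidence here accounts for this reversal.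

The compounds shown leave open whether the ring itself sets compound 4 apart or whether the branching at the carbon bound to the nitrogen does, a question that a hexyl chain, an isopropyl group or a cyclopentyl ring on the same nitrogen would bear on. They also leave open how an aromatic phenyl ring or a chain carrying an amine would sit in this order.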